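Removing one chlorine from the fused core of compound 2

The source may report more compounds than this note shows. Statements on the series, on what has been measured and on what is new or still open speak of the compounds shown alone.

Measured so far:
compound 1 `ClCc1ccccc1Cn1cnc2c(Cl)nc(Cl)nc21` gives 1820 nM in a functional assay on MCF7 cells (Homo sapiens) for cytotoxicity, read by sulforhodamine B assay, with a stated time of 48 h; on this read-out higher numbers stand for weaker inhibition of growth and lower numbers for stronger inhibition of growth
compound 2 `ClCc1ccc(Cn2cnc3nc(Cl)nc(Cl)c32)cc1` gives 17000 nM in this assay

Compound 2 is the higher of the two numbers seen so far, and its gap to compound 1 lies beyond the scatter. Compound 3 `ClCc1ccc(Cn2cnc3ncnc(Cl)c32)cc1` differs from compound 2 in one place: hydrogen in place of chloro on an aromatic carbon, on the carbon between two ring nitrogen atoms. Nothing measured yet shows the effect of this change, so the expected step in this assay is a 1.5-fold higher number from compound 2 to compound 3 (0.17 log units; within the scatter), a small move toward weaker inhibition, close to the scatter. Compound 3 is estimated at 25000 nM, within 7000 nM to 90000 nM.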

Compound 3, concentration for total growth inhibition: 2950 nM
Compound 3: middle estimate off by 8.5-fold (0.93 log units), on the high side, and the stated range ends above it.
By their numbers in this assay, from the lowest: compounds 1 and 3 (each within the scatter of the next); then compound 2.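

In this assay, replacing the chloro with hydrogen on the carbon between two ring nitrogen atoms gives a 5.8-fold lower number from compound 2 to compound 3 (0.76 log units; beyond the scatter), so growth inhibition does not depend on this chlorine and is stronger without it. Going by these compounds alone, this is the only reading of this position so far, and it rests on a single pair. No measurement shown here explains the step.

Still open, going by these compounds, is how an amine or a methoxy group on this carbon would compare with hydrogen. Also open, on these data alone, is whether removing the same chlorine from compound 1 would give a similar step.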